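A few compounds are considered here, and "the series" means these few. Any claim that something is new, unique, unknown or untested is made for them only; others in the source may bear on it.

Compound 1 `COc1ccccc1-c1cc(C2CCNC2)ccc1Cl` gives 590 nM in an assay on isolated protein for binding affinity to 5-hydroxytryptamine receptor 3A (Homo sapiens); a higher number here means a weaker inhibitor, a lower number a stronger inhibitor.
Compound 2 `COc1ccccc1-c1cc(C2CCN(C)C2)ccc1Cl` gives 420 nM in this assay.
Compound 3 `CCCCNCc1ccc(Cl)c(-c2ccccc2OC)c1` reaches only a limit in this assay, > 10000 nM.

Among the two numbers, compound 1 has the higher one, with compound 2 nearest; the move a 1.4-fold lower number from compound 1 to compound 2 (0.15 log units; within the scatter) stays within the scatter. For compound 3 the value is a limit, not a number, and it marks the same limit of > 10000 nM in this assay, at which 1 of the 3 values shown sits, for this assay.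

Compound 4 `CCCNCc1ccc(Cl)c(-c2ccccc2OC)c1` departs from compound 1 by (propylamino)methyl in place of pyrrolidin-3-yl on an aromatic carbon. Within the data shown here, the steps that bear on this are an at least 16-fold higher number from compound 1 to compound 3 (1.22 log units; beyond the scatter) and an at least 23-fold higher number from compound 2 to compound 3 (1.37 log units; beyond the scatter), both large and beyond the scatter, and both carry a compound to the limit. Compound 4 shares with compound 3 the open-chain (alkylamino)methyl pattern in place of the pyrrolidine ring, with propylamino where compound 3 has butylamino. A large step to a higher number is therefore expected, a 14-fold higher number from compound 1 to compound 4 (1.13 log units; beyond the scatter). For compound 4 the estimate in this assay is 8000 nM, between 2000 nM and 30000 nM, with a fair chance that only a limit is returned.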

Compound 4, inhibition constant: > 10000 nM
Compound 4 was reported as a limit; the forecaster's own chance of this, stated with the estimate: 50%; at least 1.2-fold (0.09 log units) between middle value and limit.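

Swapping the ring for the open chain at this aromatic carbon, para to the chloro group, gives an at least 16-fold higher number from compound 1 to compound 4 (1.22 log units; beyond the scatter), and from the N-methyl ring it gives an at least 23-fold higher number from compound 2 to compound 4 (1.37 log units; beyond the scatter), so the large loss in this assay is not tied to the butylamino chain alone. Compound 4 returns only a limit, the same one as compound 3: the limit of > 10000 nM in this assay, at which 2 of the 4 values shown sit. The step between these two compounds cannot be read from two limits, so any effect of shortening the chain stays hidden.

The compounds shown do not tell whether a shorter open chain, such as (methylamino)methyl or (ethylamino)methyl, would return a measurable number. They also leave open whether a larger ring, such as a piperidine, would keep the affinity of compound 1 and compound 2.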